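Chain-carbon substituent: cyclopropyl to 4-methylphenyl

The compounds below may be only part of what the source reports. "The series", "measured", "known", "first", "only" and "open" are said of these compounds alone.

Going by the values given here, compound 3 `O=C(O)c1ccccc1-c1ccc(CCc2ncc(CC3CC3)[nH]2)cc1` gives 1000 nM in an in vitro functional assay on cells for agonist activity at Bombesin receptor subtype-3 (Homo sapiens), read by luminescence and calcium flux (a lower number here means that less compound is needed, a higher number that more compound is needed for the effect), the second highest of the three numbers so far. Compound 2 `CC(C)(C)Cc1cnc(CCc2ccc(-c3ccccc3C(=O)O)cc2)[nH]1` gives 106 nM and compound 1 `COc1cccc(Cc2cnc(CCc3ccc(-c4ccccc4C(=O)O)cc3)[nH]2)c1` gives 4120 nM; the steps of a 9.4-fold higher number from compound 2 to compound 3 (0.97 log units; beyond the scatter) and a 4.1-fold lower number from compound 1 to compound 3 (0.61 log units; beyond the scatter) place compound 3 between them. Compound 4 `Cc1ccc(Cc2cnc(CCc3ccc(-c4ccccc4C(=O)O)cc3)[nH]2)cc1` carries 4-methylphenyl in place of cyclopropyl on a saturated chain carbon bound to an aromatic carbon. The step that bears on this is a 4.1-fold lower number from compound 1 to compound 3 (0.61 log units; beyond the scatter), in which 3-methoxyphenyl on the same carbon stood at the higher number; compound 4 runs that change in the reverse direction with 4-methylphenyl, and a 39-fold lower number from compound 1 to compound 2 (1.59 log units; beyond the scatter) likewise leaves 3-methoxyphenyl as the highest of the three. A modest rise, a 3.0-fold higher number from compound 3 to compound 4 (0.48 log units; beyond the scatter), is therefore expected for compound 4, estimated at 3000 nM with a range of 1000 nM to 9000 nM.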

Compound 4, half-maximal effective concentration: 2660 nM
Estimate against measurement, compound 4: 1.1-fold (0.05 log units) above; low and high end bracket the measured number.
By their numbers in this assay, from the lowest: compound 2; then compound 3; then compounds 4 and 1 (each within the scatter of the next).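

In this assay, two differently substituted phenyl groups on this saturated chain carbon read alike (a 1.5-fold lower number from compound 1 to compound 4 (0.19 log units; within the scatter)), so 3-methoxyphenyl is not alone at the high end. Both non-aromatic groups give lower numbers than these aromatic ones (cyclopropyl: a 2.7-fold higher number from compound 3 to compound 4 (0.42 log units; beyond the scatter); tert-butyl, by a larger margin: a 25-fold higher number from compound 2 to compound 4 (1.40 log units; beyond the scatter)). No measured evidence on the reason for this split is available.

Going by these compounds, it remains open whether a phenyl group carrying an amine would stay at the high end, and whether a longer chain ending in tert-butyl would keep the low number of compound 2.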